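The compounds below may be only part of what the source reports. "The series", "measured", "known", "first", "only" and "open" are said of these compounds alone.

Working notes on the series, followed in a functional assay (aorta) with Rattus norvegicus as the target; on this read-out higher numbers stand for an effect only at larger amounts of compound and lower numbers for an effect already at smaller amounts. Compound 1 `CC1(C)C=C(/C(S)=N\CCC#N)c2cc([N+](=O)[O-])ccc2O1` gives 0.372 nM, compound 2 `CC1(C(F)(F)F)C=C(/C(S)=N\CCC#N)c2cc([N+](=O)[O-])ccc2O1` gives 0.363 nM and compound 3 `N#CCC/N=C(/S)C1=CC(C(F)(F)F)(C(F)(F)F)Oc2ccc([N+](=O)[O-])cc21` gives 0.437 nM. Compound 2 is not separated from the other two measured compounds. The two measured steps are a 1.0-fold lower number from compound 1 to compound 2 (0.01 log units; within the scatter) and a 1.2-fold higher number from compound 2 to compound 3 (0.08 log units; within the scatter).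

Compound 4 `CC1(C(F)(F)F)C=C(C(=O)NCCC#N)c2cc([N+](=O)[O-])ccc2O1` keeps the core of compound 2 and differs in one group: a group of 7 heavy atoms (4 carbon, 2 nitrogen, 1 oxygen; no ring) in place of a group of 7 heavy atoms (4 carbon, 2 nitrogen, 1 sulfur; no ring), on a double-bonded ring carbon. The entering group is (2-cyanoethyl)carbamoyl.

Both measured steps are trifluoromethyl in place of methyl on a saturated ring carbon, which is a different change. Within the data shown here, all three measured compounds carry the leaving group, so the series holds no measured precedent for this exchange, and neither step gives its size. As a working expectation with little support, the estimated step is an 8.3-fold higher number from compound 2 to compound 4 (0.92 log units; beyond the scatter), towards a higher number and beyond the scatter. For compound 4 the estimated value in this assay is 3 nM, with an expected range from 0.4 nM to 25 nM.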

Compound 4, half-maximal effective concentration: 0.692 nM
Beside the measured number, compound 4's estimate is 4.3-fold (0.64 log units) above it; the range from low to high includes it.
By their numbers in this assay, from the lowest: compounds 2, 1, 3 and 4 (each within the scatter of the next).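

At the double-bonded ring carbon, (2-cyanoethyl)carbamoyl in place of the sulfur-containing group gives a 1.9-fold higher number from compound 2 to compound 4 (0.28 log units; within the scatter) in this assay. Among these compounds, this is the first reading at this position, as the earlier steps all concerned trifluoromethyl in place of methyl on a saturated ring carbon, and it shows that the sulfur of the leaving group is not required for a read-out within the scatter of compound 2. No measured property is available that bears on this result.

The exchange is shown only on the core of compound 2, so its outcome on the cores of compound 1 and compound 3 remains open. Also open, going by these compounds, is how this position responds to a carboxylic acid, an amine or a longer chain ending in a nitrile.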